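The source may report more compounds than this note shows. Statements on the series, on what has been measured and on what is new or still open speak of the compounds shown alone.

Working notes on the coumarin-free description of the series: all compounds share the core of compound 1, `Cc1c(OCc2ccccc2)ccc2c(N3CCNCC3)cc(=O)oc12`, and differ only in the group carried on the saturated chain carbon bound to an oxygen on the aromatic ring. In a functional assay on a cell-free system (plasma, Homo sapiens) for inhibition, with Plasma (Rattus norvegicus) as the target (a higher number here means a weaker inhibitor, a lower number a stronger inhibitor), compound 1 gives 1100 nM. Compound 2, `CCCOc1ccc2c(N3CCNCC3)cc(=O)oc2c1C`, gives 7770 nM in this assay, and compound 3, `COc1c(C)cnc(COc2ccc3c(N4CCNCC4)cc(=O)oc3c2C)c1C`, gives 5800 nM. Compound 3 thus stands second highest of the three numbers: it sits close to compound 2, from which it differs only within the scatter, and well apart from compound 1, as shown by a 5.3-fold higher number from compound 1 to compound 3 (0.72 log units; beyond the scatter).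

Compound 4, `CSCOc1ccc2c(N3CCNCC3)cc(=O)oc2c1C`, is the next member: methylsulfanyl in place of 4-methoxy-3,5-dimethylpyridin-2-yl on a saturated chain carbon bound to an oxygen on an aromatic ring. The group that enters counts two heavy atoms, so compound 4 resembles compound 2 more than compound 3 in size of the chain group. The measured steps that bear on this are a 7.1-fold higher number from compound 1 to compound 2 (0.85 log units; beyond the scatter) and a 5.3-fold higher number from compound 1 to compound 3 (0.72 log units; beyond the scatter), both modest, and a 1.3-fold lower number from compound 2 to compound 3 (0.13 log units; within the scatter), within the scatter. Replacing the larger aromatic group with a small chain group is therefore expected to give no step beyond the scatter in this assay, roughly a 1.2-fold higher number from compound 3 to compound 4 (0.08 log units; within the scatter). Compound 4 is estimated at 7000 nM, with a range of 3000 nM to 18000 nM.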

Compound 4, half-maximal inhibitory concentration: 3400 nM
For compound 4 the middle estimate is 2.1-fold (0.31 log units) above the measured one, and the stated range covers the measured number.
By their numbers in this assay, from the lowest: compound 1; then compounds 4, 3 and 2 (each within the scatter of the next, the first and the last beyond it).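

In this assay, methylsulfanyl in place of 4-methoxy-3,5-dimethylpyridin-2-yl gives no step beyond the scatter (a 1.7-fold lower number from compound 3 to compound 4 (0.23 log units; within the scatter)), whereas methylsulfanyl in place of ethyl does (a 2.3-fold lower number from compound 2 to compound 4 (0.36 log units; beyond the scatter)). At this position, the number of heavy atoms in the group therefore does not by itself order these compounds, and phenyl still gives the lowest number, with methylsulfanyl in its place giving a modest step (a 3.1-fold higher number from compound 1 to compound 4 (0.49 log units; beyond the scatter)). No measurement available here accounts for these differences.

Open, going by these compounds, is how a longer alkyl chain, or a chain ending in an amine or a carboxylic acid, would read on this saturated chain carbon. Also open, on these data alone, is whether the lower number of compound 1 would persist with a substituted phenyl.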